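The compounds below may be only part of what the source reports. "The series", "measured", "known", "first", "only" and "open" are said of these compounds alone.

The measured compounds:
- compound 1, `COc1ccc(NC(=O)CNCCCC(=O)Nc2ccccc2N)cc1`: > 100000 nM
- compound 2, `Nc1ccccc1NC(=O)c1ccc(NCC(=O)Nc2ccc([N+](=O)[O-])cc2)cc1`: > 100000 nM

In a functional assay on U-251 cells (Homo sapiens) for inhibition, read by MTT assay, with a stated time of 2 days (on this read-out higher numbers stand for lower toxicity in this test and lower numbers for higher toxicity in this test), compound 1 gives > 100000 nM, which is a limit of the assay rather than a number. In this assay compound 2 gives > 100000 nM, again a limit and not a number. Among the compounds with values here, both results sit at the limit of > 100000 nM in this assay, at which 2 of the 2 values shown sit, so compound 2 stands exactly where the only other measured compound stands, with no numerical toxicity resolved for either.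

Compound 3, `Cc1ccc(NC(=O)CNc2ccc(C(=O)Nc3ccccc3N)cc2)cc1`, has not yet been measured in this assay. It differs from compound 2 in one place: methyl in place of nitro on an aromatic carbon. Within the data shown here, no step between two measured compounds is available to calibrate such a change, so the expectation rests on where compound 2 stands alone. Compound 3 is expected to stay at or near the limit, the expected step being a number no higher from compound 2 to compound 3 (the limit leaves the size open), that is, none beyond the scatter. Compound 3 is therefore estimated at 100000 nM, within a range from 50000 nM to 300000 nM, and most probably it will be reported again only as a limit.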

Compound 3, concentration lethal to 50% of the cells: > 100000 nM
Compound 3: a limit, no number (the forecaster's own chance of this, stated with the estimate: 80%); the middle value sits exactly at the limit.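

Compound 2 and compound 3 both give a limit of the assay rather than a number, so no step can be read for methyl in place of nitro. The compounds shown leave open what numerical toxicity any of them has: the limit of > 100000 nM in this assay, at which 3 of the 3 values shown sit.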